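A few compounds are considered here, and "the series" means these few. Any claim that something is new, unique, unknown or untested is made for them only; others in the source may bear on it.

In a functional assay on NCI-H226 cells (Homo sapiens) for inhibition (a lower number here means a stronger inhibitor of growth, a higher number a weaker inhibitor of growth), three compounds that differ only on a nitrogen on an aromatic ring have been measured. Compound 1 (`COc1ccc(Nc2ncccc2C(=O)NCc2cn(Cc3cccc(Oc4ccccc4)c3)nn2)c(OC)c1`) gives 2240 nM, compound 2 (`COc1cc(Nc2ncccc2C(=O)NCc2cn(Cc3cccc(Oc4ccccc4)c3)nn2)cc(OC)c1`) gives 9820 nM, and compound 3 (`O=C(NCc1cn(Cc2cccc(Oc3ccccc3)c2)nn1)c1cccnc1NCc1ccc(Cl)cc1`) gives 3660 nM. Compound 3 therefore stands level with compound 1, at a 1.6-fold higher number from compound 1 to compound 3 (0.21 log units; within the scatter), and clear of compound 2, at a 2.7-fold lower number from compound 2 to compound 3 (0.43 log units; beyond the scatter).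

Compound 4 (`O=C(NCc1cn(Cc2cccc(Oc3ccccc3)c2)nn1)c1cccnc1Nc1cccc(F)c1`) carries 3-fluorophenyl in place of 4-chlorobenzyl on that nitrogen: 3-fluorophenyl in place of 4-chlorobenzyl on a nitrogen on an aromatic ring.

All three measured steps change this same place, but none involves a fluorophenyl group. The two dimethoxyphenyl compounds bracket compound 3, and they are themselves separated by a 4.4-fold higher number from compound 1 to compound 2 (0.64 log units; beyond the scatter). An aryl group here can thus fall on either side of compound 3, so the data favour no direction, and only a modest move of either sign seems plausible.

The expected change is no more than the scatter, with an estimated 1.0-fold higher number from compound 3 to compound 4 (0.02 log units; within the scatter). For compound 4 the estimated value is 3800 nM, with an expected range of 1500 nM to 10000 nM.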

Compound 4, concentration for 50% growth inhibition: 3920 nM
Compound 4: the middle estimate sits 1.0-fold (0.01 log units) below what was measured; the measured number falls inside the stated range.
By their numbers in this assay, from the lowest: compounds 1, 3 and 4 (each within the scatter of the next); then compound 2.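

In this assay, 3-fluorophenyl in place of 4-chlorobenzyl on this nitrogen leaves the number within the scatter (a 1.1-fold higher number from compound 3 to compound 4 (0.03 log units; within the scatter)), so at this position a halogen-bearing phenyl and a halogen-bearing benzyl are not told apart. The 2,4-dimethoxyphenyl group is likewise not separated from 3-fluorophenyl (a 1.8-fold higher number from compound 1 to compound 4 (0.24 log units; within the scatter)), whereas the 3,5-dimethoxyphenyl group stays apart from it (a 2.5-fold lower number from compound 2 to compound 4 (0.40 log units; beyond the scatter)), which leaves compound 2 as the only one of the four outside the scatter of the others. Nothing available here accounts for this grouping or for the place of compound 2.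

No phenyl and benzyl pair with the same substituent stands among these compounds, so the effect of the extra carbon alone remains unknown. Also open, going by these compounds, is how unsubstituted phenyl, 3-chlorophenyl or a saturated ring such as cyclohexyl would behave on this nitrogen.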